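Succinimide propanamides and butanamides: the step to compound 4

The source may report more compounds than this note shows. Statements on the series, on what has been measured and on what is new or still open speak of the compounds shown alone.

Of the compounds shown here, three have a number so far. Compound 1 `CC(C(=O)NCc1ccccc1Cl)N1C(=O)CCC1=O` gives 74.5 mg/kg in a functional assay on the whole organism (strain Albino Swiss CD1) with Mus musculus as the target, in the maximal electroshock model; on this read-out lower numbers stand for an effect already at smaller amounts and higher numbers for an effect only at larger amounts of compound. Compound 2 `CC(C(=O)NCc1cccc(C(F)(F)F)c1)N1C(=O)CCC1=O` gives 92.4 mg/kg in this assay. Compound 3 `CCC(C(=O)NCc1ccccc1)N1C(=O)CCC1=O` gives 73.3 mg/kg in this assay, the lowest of the three numbers, yet compound 1 sits within the scatter of it and compound 2 also sits within the scatter of it, so no order among the three can be read from these values.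

Compound 4 `CCC(C(=O)NCc1ccccc1Cl)N1C(=O)CCC1=O` is not yet measured. It differs from compound 3 in one place: chloro in place of hydrogen on an aromatic carbon, ortho to a large group. Among the measured compounds shown here, no pair of measured compounds differs by this change alone; compound 1 and compound 3 differ in two places at once, and both give numbers within the scatter of each other, which leaves nothing to suggest a move beyond the scatter. For compound 4 the expected step from compound 3 is a 1.0-fold lower number from compound 3 to compound 4 (0.02 log units; within the scatter), that is, none beyond the scatter. Compound 4 is therefore estimated at 70 mg/kg in this assay, with a likely range from 40 mg/kg to 125 mg/kg.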

Compound 4, dose for half-maximal effect: 113 mg/kg
Estimate against measurement, compound 4: 1.6-fold (0.21 log units) below, within the range that was stated.
By their numbers in this assay, from the lowest: compounds 3, 1, 2 and 4 (each within the scatter of the next).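

With the rest of the structure held, chloro in place of hydrogen on an aromatic carbon, ortho to a large group, now has a step of its own in this assay: phenyl to 2-chlorophenyl gives a 1.5-fold higher number from compound 3 to compound 4 (0.19 log units; within the scatter) and so shows no readable effect at this position. With the 2-chlorophenyl group held, methyl in place of hydrogen on the saturated chain carbon gives a 1.5-fold higher number from compound 1 to compound 4 (0.18 log units; within the scatter) and so adds a second single change that cannot be told from the scatter. Nothing at hand bears on the cause of either step.

Still open, as far as these compounds go, is whether a methoxy group, an amine or a carboxylic acid on that aromatic carbon would move the number beyond the scatter. Also open, from the compounds shown here alone, is whether a longer chain on the saturated carbon would do so.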